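Acetyl in place of hydroxy: compound 4 from compound 3

The compounds below may be only part of what the source reports. "The series", "measured", "known", "first", "only" and "open" are said of these compounds alone.

Compound 1 `O=C(CSC(=S)N[C@H]1CCOC1=O)Nc1ccccc1` in a functional assay on MCF7 cells (Homo sapiens) for cytotoxicity, read by MTT assay, with a stated time of 72 h (a higher number here means a weaker inhibitor, a lower number a stronger inhibitor), gives > 128000 nM, a limit of the assay.
Compound 2 `O=C(CSC(=S)N[C@H]1CCOC1=O)Nc1ccc(F)cc1` in this assay gives 5830 nM.
Compound 3 `O=C(CSC(=S)N[C@H]1CCOC1=O)Nc1ccc(O)cc1` in this assay gives > 128000 nM, a limit of the assay.

Compound 3 therefore stands at the limit, where (the limit of > 128000 nM in this assay, at which 2 of the 3 values shown sit), and its own number is not known. Compound 4 `CC(=O)c1ccc(NC(=O)CSC(=S)N[C@H]2CCOC2=O)cc1` differs from it by acetyl in place of hydroxy on an aromatic carbon. Two readable steps bear on this change: an at least 21-fold lower number from compound 1 to compound 2 (1.34 log units; beyond the scatter) and an at least 21-fold higher number from compound 2 to compound 3 (1.34 log units; beyond the scatter), whereas a step that the two limits leave unreadable from compound 1 to compound 3. A group at this place can thus bring the number down to a reading or leave it at the limit, and the acetyl group has no measured neighbour among these compounds. Compound 4 is expected to show an at least 3.2-fold lower number from compound 3 to compound 4 (0.50 log units; beyond the scatter), possibly remaining a limit. Compound 4 is estimated at 40000 nM, with an expected range from 6000 nM to 150000 nM.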

Compound 4, half-maximal inhibitory concentration: > 128000 nM
Compound 4 was reported as a limit; the forecaster's own chance of this, stated with the estimate: 45%; at least 3.2-fold (0.50 log units) between middle value and limit.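

With acetyl in place of fluoro on the aromatic carbon, this assay shows an at least 21-fold higher number from compound 2 to compound 4 (1.34 log units; beyond the scatter), so acetyl, like hydroxy, does not keep the reading that compound 2 has. Compound 2 is thus the only one of the four with a reading at this position, and it alone goes against the run of limits. The steps from compound 3 and from compound 1 to compound 4 cannot be read, because both ends of each are limits: the limit of > 128000 nM in this assay, at which 3 of the 4 values shown sit.

From the compounds shown here alone, the order among compound 1, compound 3 and compound 4 stays open. So does whether chloro, methoxy or an amine at this place would give a reading as fluoro does.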